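Pyridin-3-yl in place of pyridin-4-yl in compound 3

The source may hold more compounds than are shown below. What is called first, only, known or untested is meant among the compounds shown, and "the series" means these compounds.

In a functional assay on A498 cells (Homo sapiens) for antiproliferative activity (on this read-out lower numbers stand for stronger inhibition of growth and higher numbers for weaker inhibition of growth), compound 1 `c1ccc(-c2cc(-c3cccnc3)nc(-c3ccccn3)c2)cc1` gives 0.074 ug/mL, compound 2 `c1ccc(-c2cc(-c3ccsc3)cc(-c3cccnc3)n2)nc1` gives 0.64 ug/mL and compound 3 `c1ccc(-c2cc(-c3cccs3)cc(-c3ccncc3)n2)nc1` gives 0.84 ug/mL. Compounds 2 and 3 lie within the scatter of each other, and both stand clearly above compound 1. Compound 4 `c1ccc(-c2cc(-c3cccs3)cc(-c3cccnc3)n2)nc1` comes from compound 3 by a single change: pyridin-3-yl in place of pyridin-4-yl on an aromatic carbon. For the measured compounds named here, no measured step covers this swap. The only one, an 8.6-fold higher number from compound 1 to compound 2 (0.94 log units; beyond the scatter), exchanges a different group, so it sets no size here. The closest guide is compound 2, which also carries pyridin-3-yl, with thiophen-3-yl, and gives 0.64 ug/mL. The expected change is a 1.2-fold lower number from compound 3 to compound 4 (0.08 log units; within the scatter), nothing beyond the scatter. Compound 4 is estimated at 0.7 ug/mL, with a range of 0.25 ug/mL to 2 ug/mL.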

Compound 4, concentration for 50% growth inhibition: 0.0029 ug/mL
For compound 4 the middle estimate is 240-fold (2.38 log units) above the measured one; measured number outside the range, below it.
By their numbers in this assay, from the lowest: compound 4; then compound 1; then compounds 2 and 3 (each within the scatter of the next).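

With thiophen-2-yl kept in place, swapping pyridin-4-yl for pyridin-3-yl gives a very large change (a 290-fold lower number from compound 3 to compound 4 (2.46 log units; beyond the scatter)), so two groups with identical atom counts are far from interchangeable at this position. With pyridin-3-yl kept, the thiophene's point of attachment also counts (a 220-fold lower number from compound 2 to compound 4 (2.34 log units; beyond the scatter)), and thiophen-2-yl outdoes phenyl as well (a 26-fold lower number from compound 1 to compound 4 (1.41 log units; beyond the scatter)). Nothing shown here explains these steps. Open, from the compounds shown here alone, is whether an amine or a methoxy group on the thiophen-2-yl ring would keep the number this low.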